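Trimming the Amine Substituent: Expected Cytotoxicity of Compound 3

The source may report more compounds than this note shows. Statements on the series, on what has been measured and on what is new or still open speak of the compounds shown alone.

Two measured compounds share one core. Compound 1 `COC(=O)C(=O)CNC1=CS(=O)(=O)O[C@@]12[C@@H](CO[Si](C)(C)C(C)(C)C)O[C@@H](n1cc(C)c(=O)n(C)c1=O)[C@@H]2O[Si](C)(C)C(C)(C)C` carries a (methoxycarbonyl)carbonyl group on the chain at the amine nitrogen. In a functional assay on HEL cells (Homo sapiens) for cytotoxicity, read by microscopy (on this read-out higher numbers stand for lower toxicity in this test and lower numbers for higher toxicity in this test), compound 1 gives only a limit of the assay, > 400000 nM. Compound 2 `Cc1cn([C@@H]2O[C@H](CO[Si](C)(C)C(C)(C)C)[C@@]3(OS(=O)(=O)C=C3NCCC(N)=O)[C@H]2O[Si](C)(C)C(C)(C)C)c(=O)n(C)c1=O` differs from compound 1 in one place, carbamoylmethyl in place of (methoxycarbonyl)carbonyl on a saturated chain carbon bound to an amine nitrogen, and the step that the two limits leave unreadable from compound 1 to compound 2 cannot be read, since two limits bound it. In this assay compound 2 likewise gives only a limit, >= 80000 nM. Compound 2 therefore stands at a limit of the assay, with no number of its own to compare.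

Compound 3 `CC(=O)NC1=CS(=O)(=O)O[C@@]12[C@@H](CO[Si](C)(C)C(C)(C)C)O[C@@H](n1cc(C)c(=O)n(C)c1=O)[C@@H]2O[Si](C)(C)C(C)(C)C` follows by a single change: acetyl in place of 2-carbamoylethyl on an amine nitrogen. Going by the values given here, the only measured step, a step that the two limits leave unreadable from compound 1 to compound 2, is unreadable and so offers no size to transfer to this assay. The expected step that the limit leaves unreadable from compound 2 to compound 3 is none beyond the scatter, because compound 2 sits at the limit of >= 80000 nM in this assay, at which 1 of the 2 values shown sits, and compound 1 sits at the limit of > 400000 nM in this assay, at which 1 of the 2 values shown sits. Compound 3 is thus expected at 100000 nM, with a range from 30000 nM to 400000 nM.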

Compound 3, minimum cytotoxic concentration: >= 80000 nM
Compound 3: no number, only a limit; the forecaster's own chance of this, stated with the estimate: 75%; the middle value does not contradict the limit.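

In this assay compound 3 gives only a limit, >= 80000 nM. Going by these compounds alone, compound 1, compound 2 and compound 3 thus all stand at limits, and no step among them can be read. The compounds shown leave open whether changing the substituent on the amine nitrogen shifts the minimum cytotoxic concentration at all, with none of them giving a number of its own.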